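Methylating One Hydroxy Group of Compound 2

The source may hold more compounds than are shown below. What is called first, only, known or untested is meant among the compounds shown, and "the series" means these compounds.

Of the compounds shown here, two from this series have been tested in a functional assay on HepG2 cells (Homo sapiens) for cytotoxicity, read by MTT assay, with a stated time of 48 h; on this read-out lower numbers stand for stronger inhibition and higher numbers for weaker inhibition. Compound 1 `O=C(CSc1nnc(-c2ccncc2)o1)N/N=C/c1ccccc1[N+](=O)[O-]` gives 24700 nM. Compound 2 `O=C(CSc1nnc(-c2ccncc2)o1)N/N=C/c1ccc(O)c(O)c1` gives 760 nM, the lowest of the two numbers. Among the compounds with values here, the only step between them, a 33-fold lower number from compound 1 to compound 2 (1.51 log units; beyond the scatter), exchanges the whole aryl group on the carbon with a double bond to nitrogen, and compound 2 stands at the far end of it. Compound 3 `COc1cc(/C=N/NC(=O)CSc2nnc(-c3ccncc3)o2)ccc1O` remains to be measured; it differs from compound 2 by methyl in place of hydrogen on an oxygen on an aromatic ring. The change from compound 1 to compound 2 bears on this only loosely, since it moved the whole aryl group and was large, whereas the step to compound 3 keeps the 4-hydroxy group and caps only the other oxygen. Since the low number of compound 2 arrived together with the 3,4-dihydroxyphenyl group, a modest move back toward higher numbers is expected for compound 3, estimated as a 2.4-fold higher number from compound 2 to compound 3 (0.37 log units; beyond the scatter). Compound 3 is therefore expected to give about 1800 nM, within a range from 500 nM to 6500 nM.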

Compound 3, half-maximal inhibitory concentration: 2920 nM
For compound 3 the middle estimate is 1.6-fold (0.21 log units) below the measured one; low and high end bracket the measured number.
By their numbers in this assay, from the lowest: compound 2; then compound 3; then compound 1.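

Methyl in place of hydrogen on this oxygen gives a 3.8-fold higher number from compound 2 to compound 3 (0.58 log units; beyond the scatter) in this assay, so a single added carbon on the 3,4-dihydroxyphenyl group is enough to move the number beyond the scatter, while the 4-hydroxy group stays in place. The 4-hydroxy-3-methoxyphenyl group nevertheless keeps a large part of the gain over the 2-nitrophenyl group, with an 8.5-fold lower number from compound 1 to compound 3 (0.93 log units; beyond the scatter), so the low numbers in this series do not depend entirely on this hydroxy group being free. No measurement is available that would explain the shift seen on capping this oxygen.

The compounds shown leave open whether an ethyl group or a longer chain on the same oxygen would raise the number further, or whether an amine or a fluorine in place of the whole hydroxy group would give a similar result. They also leave open what methyl on the oxygen of the 4-hydroxy group would do, and whether capping both oxygens as a 3,4-dimethoxyphenyl group would add to the step seen here.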